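Swapping the tetramethylbutyl group for nitro in compound 2

This account rests on a few compounds, and the source may have more. Where it says the series, first, only, none or still open, it means among the compounds named here.

Measured compounds:
compound 1 `C#CCOC(=O)c1ccc(O)c(NC(=O)COc2ccc(C(C)(C)CC(C)(C)C)cc2)c1` 5880 nM
compound 2 `COC(=O)c1cccc(NC(=O)COc2ccc(C(C)(C)CC(C)(C)C)cc2)c1` 8920 nM
compound 3 `COCCOc1ccc(C(=O)OC)cc1NC(=O)COc1ccc(C(C)(C)CC(C)(C)C)cc1` 29000 nM

The study concerns three compounds that share a core and were tested in an assay on isolated protein for inhibition of malate dehydrogenase, mitochondrial (Homo sapiens), with a stated time of 30 min; on this read-out lower numbers stand for stronger inhibition and higher numbers for weaker inhibition. Compound 2 `COC(=O)c1cccc(NC(=O)COc2ccc(C(C)(C)CC(C)(C)C)cc2)c1` gives 8920 nM, the second highest of the three numbers; compound 1 gives 5880 nM, which lies within the scatter of compound 2, while compound 3 gives 29000 nM. Going by the values given here, the only single-point step among the measured compounds is a 3.3-fold higher number from compound 2 to compound 3 (0.51 log units; beyond the scatter), where 2-methoxyethoxy enters in place of hydrogen on an aromatic carbon.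

The unmeasured compound 4 `COC(=O)c1cccc(NC(=O)COc2ccc([N+](=O)[O-])cc2)c1` differs from compound 2 in another way: nitro in place of 1,1,3,3-tetramethylbutyl on an aromatic carbon. The change sits on an aromatic carbon of a six-membered aromatic ring of carbon only, para to a large group. Among the compounds with values here, no measured step touches this position or this pair of groups, so there is no comparison to anchor the expected step. The estimate for compound 4 therefore rests on the value of compound 2 alone, widened to cover a larger step in either direction. Compound 4 is expected to give 20000 nM, within a range from 4000 nM to 100000 nM. This estimate amounts to an expected step of a 2.2-fold higher number from compound 2 to compound 4 (0.35 log units; beyond the scatter).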

Compound 4, half-maximal inhibitory concentration: > 40000 nM
Compound 4 ended at the assay's limit; the forecaster's own chance of this, stated with the estimate: 25%; middle value at least 2.0-fold (0.30 log units) from the limit.
By their numbers in this assay, from the lowest: compounds 1 and 2 (each within the scatter of the next); then compound 3. At a limit, above all of these: compound 4.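

Compound 4 carries a limit of the assay rather than a number in this assay: the limit of > 40000 nM in this assay, at which 1 of the 4 values shown sits. Until now every compound kept 1,1,3,3-tetramethylbutyl, so this position had not been tested; the result shows that inhibition depends on what sits there, with an at least 4.4-fold higher number from compound 2 to compound 4 (0.65 log units; beyond the scatter). The swap of 1,1,3,3-tetramethylbutyl for nitro therefore weakens inhibition beyond the scatter, although the limit fixes only a minimum for the step and not its true size.

The compounds shown leave open whether that loss follows from removing the 1,1,3,3-tetramethylbutyl group or from introducing nitro, and a tert-butyl group or an amine on this aromatic carbon would help to separate the two. Nor do they show whether any other group at this position can match 1,1,3,3-tetramethylbutyl.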